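Iodo for methoxy in a second setting of the shared core

The source may report more compounds than this note shows. Statements on the series, on what has been measured and on what is new or still open speak of the compounds shown alone.

Compound 1 `Cc1ccc(NC(=O)c2ccc(I)cc2OCCCCn2ccnc2)cc1Nc1nccc(-c2cccnc2)n1`: 51800 nM
Compound 2 `COc1cc(C(=O)Nc2ccc(C)c(Nc3nccc(-c4cccnc4)n3)c2)ccc1OCCCCn1ccnc1`: 27100 nM
Compound 3 `COc1ccc(C(=O)Nc2ccc(C)c(Nc3nccc(-c4cccnc4)n3)c2)c(OCCCCn2ccnc2)c1`: 46600 nM

Three compounds were measured in a functional assay on K-562R cells (Homo sapiens) for cytotoxicity, read by XTT assay, with a stated time of 24 h; on this read-out lower numbers stand for stronger inhibition and higher numbers for weaker inhibition. Compound 1 gives 51800 nM in this assay, compound 2 gives 27100 nM, and compound 3 gives 46600 nM. The three numbers lie close together: compound 2 has the lowest number of the three, but its distance to compound 3 and to compound 1 is within the scatter, so no order among them can be claimed.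

Compounds 3 and 1 differ in one place, (iodo in place of methoxy on an aromatic carbon), and the step is a 1.1-fold higher number from compound 3 to compound 1 (0.05 log units; within the scatter). Compound 2 and compound 3 share the same atoms joined differently; the difference between the two cores is not broken down here.

Compound 4 `Cc1ccc(NC(=O)c2ccc(OCCCCn3ccnc3)c(I)c2)cc1Nc1nccc(-c2cccnc2)n1` has not yet been measured. It differs from compound 2 by iodo in place of methoxy on an aromatic carbon. This is the same kind of change as that from compound 3 to compound 1, but not the same: in compound 4 the iodo sits ortho to the 4-(1H-imidazol-1-yl)butoxy group and meta to a large group, whereas in compound 1 it sits meta to the 4-(1H-imidazol-1-yl)butoxy group and para to a large group.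

Because the earlier step was a 1.1-fold higher number from compound 3 to compound 1 (0.05 log units; within the scatter), the step from compound 2 to compound 4 is expected to be small as well, about a 1.1-fold higher number from compound 2 to compound 4 (0.04 log units; within the scatter). Compound 4 is therefore estimated at 30000 nM in this assay, with a likely range from 13000 nM to 70000 nM.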

Compound 4, half-maximal inhibitory concentration: 52400 nM
Estimate against measurement, compound 4: 1.7-fold (0.24 log units) below; low and high end bracket the measured number.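

In this assay, putting iodo in place of methoxy on the aromatic carbon ortho to the 4-(1H-imidazol-1-yl)butoxy group and meta to a large group gives a 1.9-fold higher number from compound 2 to compound 4 (0.29 log units; within the scatter), so this second step, like the first, gives no sign that the change moves the number. Within the data shown here, these results do not establish that iodo and methoxy are interchangeable in general, since they rest on only two cores in a single cell assay, and steps this small cannot reveal a modest effect of the change or a modest difference between its effects on the two cores. As far as these two cases go, the change carries from one core to the other without a difference that can be told from scatter, and the comparison of the two steps supports no more than that: the same change on two cores in this assay, a 1.1-fold higher number (0.05 log units; within the scatter) from compound 3 to compound 1 and a 1.9-fold higher number (0.29 log units; within the scatter) from compound 2 to compound 4, 1.7-fold (0.24 log units) apart, within the scatter of two such steps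

The compounds shown leave open whether a different group at these aromatic carbons, such as an amine or a carboxylic acid, would give a step beyond the scatter. They also leave open whether a chain longer than the 4-(1H-imidazol-1-yl)butoxy group would alter the numbers in this assay on either core.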